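This account rests on a few compounds, and the source may have more. Where it says the series, first, only, none or still open, it means among the compounds named here.

Compound 1 `CC(C)(C)C(=O)OCC1(CO)C/C(=C\CCCCCCCCCCCCCCC=O)C(=O)O1`: > 10 ug/mL
Compound 2 `CC(=O)OCCCCCCCCCCCCCCC/C=C1\CC(CO)(COC(=O)C(C)(C)C)OC1=O`: > 10 ug/mL

In a functional assay on Hs-578T cells (Homo sapiens) for antiproliferative activity (a lower number here means a stronger inhibitor of growth, a higher number a weaker inhibitor of growth), compound 1 gives > 10 ug/mL, which is a limit and not a number. Compound 2 gives > 10 ug/mL, also a limit. Its position is therefore (the limit of > 10 ug/mL in this assay, at which 2 of the 2 values shown sit).

Compound 3 `CC(C)(C)C(=O)OCCCCCCCCCCCCCCC/C=C1\CC(CO)(COC(=O)C(C)(C)C)OC1=O` has tert-butyl in place of methyl on a carbonyl carbon. Among the compounds with values here, the only measured step, a step that the two limits leave unreadable from compound 1 to compound 2, involves another change and cannot be sized, so it offers no guide to size or direction. No shift beyond the scatter is expected in this assay, and the estimated step is a step that the limit leaves unreadable from compound 2 to compound 3. For compound 3 the estimated value is 12 ug/mL, with an expected range of 4 ug/mL to 30 ug/mL.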

Compound 3, concentration for 50% growth inhibition: 5.24 ug/mL
Compound 3: the middle estimate sits 2.3-fold (0.36 log units) above what was measured; the range from low to high includes it.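

In this assay compound 3 gives 5.24 ug/mL, a measured number and not a limit. The other two compounds stay at a limit: the limit of > 10 ug/mL in this assay, at which 2 of the 3 values shown sit.

Tert-butyl in place of methyl on the carbonyl carbon gives an at least 1.9-fold lower number from compound 2 to compound 3 (0.28 log units; that floor lies within the scatter), and the wider change at the chain end gives an at least 1.9-fold lower number from compound 1 to compound 3 (0.28 log units; that floor lies within the scatter), so each step has a floor, though not yet a size beyond the scatter.

As far as these compounds go, the true size of both steps stays open. So does what another group on this carbonyl carbon, such as a phenyl ring or an amine, would give.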